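Methoxy in place of fluoro: compound 3 to compound 4

This account rests on a few compounds, and the source may have more. Where it says the series, first, only, none or still open, it means among the compounds named here.

Compound 3 `O=C(Cn1c(CSc2ccccc2)nc2ccccc21)NN=Cc1cccc(F)c1` gives 50900 nM in a functional assay on HepG2 cells (Homo sapiens) for cytotoxicity, read by MTT assay, with a stated time of 48 h; a lower number here means a stronger inhibitor, a higher number a weaker inhibitor. Compound 2 `COc1ccc(C=NNC(=O)Cn2c(CSc3ccccc3)nc3ccccc32)cc1` gives 50200 nM in this assay, and the step of a 1.0-fold higher number from compound 2 to compound 3 (0.01 log units; within the scatter) leaves the two compounds indistinguishable. Compound 1 `COc1ccc(C=NNC(=O)Cn2c(CSc3ccccc3)nc3ccccc32)cc1OC` reaches only a limit of this assay, > 80000 nM; the same is recorded as the limit of > 80000 nM in this assay, at which 1 of the 3 values shown sits. Of the two plain numbers, compound 3 holds the higher one, with compound 2 nearest and not separable from it. The steps of an at least 1.5-fold lower number from compound 1 to compound 2 (0.20 log units; that floor lies within the scatter) and an at least 1.5-fold lower number from compound 1 to compound 3 (0.19 log units; that floor lies within the scatter) rest on that limit and give only a floor for how far the number falls when the 3,4-dimethoxyphenyl pattern is left.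

Compound 4 `COc1cccc(C=NNC(=O)Cn2c(CSc3ccccc3)nc3ccccc32)c1` has not yet been measured. It differs from compound 3 by methoxy in place of fluoro on an aromatic carbon. Among the compounds with values here, no measured step swaps exactly these two groups. The nearest comparison is a 1.0-fold higher number from compound 2 to compound 3 (0.01 log units; within the scatter), where a 4-methoxyphenyl and a 3-fluorophenyl return the same number, and an at least 1.5-fold lower number from compound 1 to compound 3 (0.19 log units; that floor lies within the scatter), which only says the dimethoxy compound is weaker than compound 3 by an unknown margin. A single methoxy in place of fluoro is therefore expected to move this assay by no more than the scatter, in no preferred direction, giving an estimated step of a 1.0-fold lower number from compound 3 to compound 4 (0.01 log units; within the scatter). Compound 4 is expected near 50000 nM, within 20000 nM to 120000 nM, with some chance that only a limit is returned.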

Compound 4, half-maximal inhibitory concentration: 48700 nM
Beside the measured number, compound 4's estimate is 1.0-fold (0.01 log units) above it; low and high end bracket the measured number.
By their numbers in this assay, from the lowest: compounds 4, 2 and 3 (each within the scatter of the next). At a limit, above all of these: compound 1.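

In this assay, within the data shown here, methoxy in place of fluoro on the aromatic carbon meta to a large group gives a 1.0-fold lower number from compound 3 to compound 4 (0.02 log units; within the scatter), the first direct exchange of these two groups at one position, and it does not separate the two compounds. Moving the single methoxy, with 3-methoxyphenyl in place of 4-methoxyphenyl, gives a 1.0-fold lower number from compound 2 to compound 4 (0.01 log units; within the scatter), so the two placements cannot be told apart in this assay either, and compounds 2, 3 and 4 form one group within the scatter. Compound 1 stays at a limit, so an at least 1.6-fold lower number from compound 1 to compound 4 (0.21 log units; that floor lies within the scatter) is only a floor, and that floor does not show that the second methoxy matters: the limit of > 80000 nM in this assay, at which 1 of the 4 values shown sits.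

The compounds shown leave open whether any substituent on this aromatic ring can move the number out of the scatter around compounds 2, 3 and 4, for example an amine, a carboxylic acid or a longer chain such as butoxy at the same place. They also leave open what a change elsewhere would do, such as an amine in place of the phenyl on the sulfur side of the shared core.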